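The compounds below may be only part of what the source reports. "The series", "measured", "known", "first", "only" and "open" are said of these compounds alone.

Measured in a physicochemical assay; a lower number here means that less compound is needed, a higher number that more compound is needed for the effect:
- compound 1 `COc1cc(/C=N/NC(=O)c2nn(-c3ccc(Cl)cc3Cl)c(-c3ccc(Cl)cc3)c2C)ccc1O`: 3550000 nM
- compound 2 `COc1cc(/C=N/NC(=O)c2nn(-c3ccc(F)c(Cl)c3)c(-c3ccc(Cl)cc3)c2C)ccc1O`: 3560000 nM
- compound 3 `COc1cc(/C=N/NC(=O)c2nn(-c3ccc(C(F)(F)F)cc3)c(-c3ccc(Cl)cc3)c2C)ccc1O`: 2340000 nM

Compound 1 cannot be separated from the other two on these numbers. The nearest is a 1.0-fold higher number from compound 1 to compound 2 (0.00 log units; within the scatter), and the furthest is a 1.5-fold lower number from compound 1 to compound 3 (0.18 log units; within the scatter). The remaining pair gives a 1.5-fold lower number from compound 2 to compound 3 (0.18 log units; within the scatter), so the three values form a single group within the scatter.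

Compound 4 `COc1cc(/C=N/NC(=O)c2nn(-c3ccc(Cl)cc3Cl)c(-c3ccc(C(F)(F)F)cc3)c2C)ccc1O` is still to be measured. It differs from compound 1 by trifluoromethyl in place of chloro on an aromatic carbon, or 4-chlorophenyl to 4-(trifluoromethyl)phenyl.

Among the compounds with values here, no measured step makes this change at this place, since compound 1, compound 2 and compound 3 all keep the 4-chlorophenyl. The closest guides are the steps that bring in 4-(trifluoromethyl)phenyl on the aromatic nitrogen, a 1.5-fold lower number from compound 1 to compound 3 (0.18 log units; within the scatter) and a 1.5-fold lower number from compound 2 to compound 3 (0.18 log units; within the scatter). Both stay within the scatter, but they concern a different place on the core, so they offer only indirect support. In this assay, no shift beyond the scatter is therefore expected, and no direction can be argued with confidence.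

The expected step is a 1.2-fold lower number from compound 1 to compound 4 (0.07 log units; within the scatter). For compound 4 the estimated value is 3000000 nM, with an expected range of 1400000 nM to 6000000 nM.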

Compound 4, half-maximal effective concentration: 4240000 nM
For compound 4 the middle estimate is 1.4-fold (0.15 log units) below the measured one, and the stated range covers the measured number.
By their numbers in this assay, from the lowest: compounds 3, 1, 2 and 4 (each within the scatter of the next).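

In this assay, within the data shown here, the change from 4-chlorophenyl to 4-(trifluoromethyl)phenyl gives the first direct reading at this place, on an aromatic carbon para to a large group: a 1.2-fold higher number from compound 1 to compound 4 (0.08 log units; within the scatter). Compounds 1, 2 and 3 all keep the 4-chlorophenyl and differ only in the aryl group on the aromatic nitrogen, so they could say nothing about this position; the exchange of chloro for trifluoromethyl now shows that this position, too, gives no separable shift for this one change. No measurement on hand offers an explanation for this flat result, which is therefore recorded only as an observation.

Still open, on these data alone, is whether this position stays equally flat with a different kind of group in place of chloro, such as an amine, a carboxylic acid or a longer alkyl chain. Also open, as far as these compounds go, is whether the exchange of chloro for trifluoromethyl reads the same when the aromatic nitrogen carries 3-chloro-4-fluorophenyl or 4-(trifluoromethyl)phenyl instead of 2,4-dichlorophenyl.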